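A few compounds are considered here, and "the series" means these few. Any claim that something is new, unique, unknown or untested is made for them only; others in the source may bear on it.

Measured compounds:
Compound 1 `CC(C)C(c1ccc(-c2ccc3cccc(F)c3c2)[nH]c1=O)N1CCCCS1(=O)=O` — 122 nM
Compound 2 `CC(C)C(c1ncco1)c1ccc(-c2ccc3cccc(F)c3c2)[nH]c1=O` — 64 nM
Compound 3 `CC(C)C(c1cnc(N)s1)c1ccc(-c2ccc3cccc(F)c3c2)[nH]c1=O` — 39 nM

The three compounds share one core and differ only in the group on a saturated chain carbon bound to an aromatic carbon and a saturated chain carbon. In a functional assay on CHO cells for antagonist activity at prostaglandin E2 receptor EP3 subtype (Homo sapiens), read by cAMP accumulation (a lower number here means a stronger inhibitor, a higher number a weaker inhibitor), compound 1 gives the highest of the three numbers. Its nearest neighbour is compound 2, with a 1.9-fold lower number from compound 1 to compound 2 (0.28 log units; within the scatter); the furthest is compound 3, with a 3.1-fold lower number from compound 1 to compound 3 (0.50 log units; beyond the scatter). Between compound 2 and compound 3 the step is a 1.6-fold lower number from compound 2 to compound 3 (0.22 log units; within the scatter).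

Compound 4 `CC(C)C(/C=C1/CCNC1=O)c1ccc(-c2ccc3cccc(F)c3c2)[nH]c1=O` has not been measured in this assay. Against compound 1 the change is a group of 7 heavy atoms (5 carbon, 1 nitrogen, 1 oxygen; one five-membered non-aromatic ring with 1 hetero atom) in place of a group of 8 heavy atoms (4 carbon, 1 nitrogen, 2 oxygen, 1 sulfur; one six-membered non-aromatic ring with 2 hetero atoms), on a saturated chain carbon bound to an aromatic carbon and a saturated chain carbon. The two measured steps from compound 1 both replace the same group at the same place with a five-membered ring, and both lowered the number, one within the scatter and one modestly beyond it. The group entering in compound 4 is a five-membered non-aromatic ring with one hetero atom, carrying a hydrogen-bond donor, so it is a different kind of replacement, and the two steps give only a loose guide. For compound 4 a step of about a 1.7-fold lower number from compound 1 to compound 4 (0.24 log units; within the scatter) is expected, a lowering within or near the scatter. Compound 4 is therefore estimated at 70 nM, with a range from 30 nM to 200 nM.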

Compound 4, half-maximal inhibitory concentration: 8.1 nM
Compound 4: middle estimate off by 8.6-fold (0.94 log units), on the high side, and the stated range ends above it.
By their numbers in this assay, from the lowest: compound 4; then compounds 3, 2 and 1 (each within the scatter of the next, the first and the last beyond it).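

At this place, on a saturated chain carbon bound to an aromatic carbon and a saturated chain carbon, the earlier replacements had shown only small to modest gains in this assay, whereas the five-membered non-aromatic ring with 1 hetero atom gives a 15-fold lower number from compound 1 to compound 4 (1.18 log units; beyond the scatter). Within the data shown here, the non-aromatic group also improves on both five-membered aromatic rings, with a 4.8-fold lower number from compound 3 to compound 4 (0.68 log units; beyond the scatter) and a 7.9-fold lower number from compound 2 to compound 4 (0.90 log units; beyond the scatter), so the position's response depends on more than replacing the six-membered ring with a five-membered one, and compound 4 is the only compound here whose steps to all the others lie beyond the scatter. No measurement available here accounts for the size of this gain, so the result stands as an observation only.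

The compounds shown leave open which feature of the entering group goes with the lower number, since its ring, its amide and its double bond change together in a single step. Whether an open-chain amide or a six-membered lactam at the same place would match compound 4 also remains unanswered.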